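The compounds below may be only part of what the source reports. "The series", "measured", "known", "first", "only" and "open" are said of these compounds alone.

Of the compounds shown here, three have been measured here in a functional assay on the whole organism (Tail, strain ICR) with Mus musculus as the target, in the tail flick test, with a stated time of 30 min, at a dose of 25 umol/kg by the oral route (a higher number here means a stronger effect of the compound at the dose given, a lower number a weaker effect), and a fourth awaits its number. Compound 1, `O=C(CN(c1nc(Cl)nc2[nH]cnc12)C1CC1)N[C@@H](CO)C(=O)OCc1ccccc1`, gives 31.9% in this assay. Compound 2, `C[C@@H](O)[C@H](NC(=O)CN(c1nc(Cl)nc2[nH]cnc12)C1CC1)C(=O)OCc1ccccc1`, gives 21.9%. Compound 3, `C[C@@H](O)[C@H](NC(=O)CN(c1ncnc2c1ncn2C1CCCCO1)C1CC1)C(=O)OCc1ccccc1`, gives 23.6%; the values of compound 3 and compound 2 lie close together, and the difference between the two cores is not broken down here.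

Compound 1 and compound 2 differ in one place only: the change is hydrogen in place of methyl on a saturated chain carbon bound to an oxygen on a saturated carbon and a saturated chain carbon, and the step it made was a number 10 percentage points higher from compound 2 to compound 1 (within the scatter).

Compound 4, `O=C(CN(c1ncnc2c1ncn2C1CCCCO1)C1CC1)N[C@@H](CO)C(=O)OCc1ccccc1`, is yet to be measured. It stands to compound 3 exactly as compound 1 stands to compound 2: the change is hydrogen in place of methyl on a saturated chain carbon bound to an oxygen on a saturated carbon and a saturated chain carbon, the same change on the same kind of place, with the core of compound 3 carried over unchanged. Within the data shown here, because the one earlier instance, a number 10 percentage points higher from compound 2 to compound 1 (within the scatter), stayed within the usual scatter, the expected step in this assay from compound 3 to compound 4 is a number 6.4 percentage points higher from compound 3 to compound 4 (within the scatter), a rise of about the same size, though a single prior step is a thin basis and a smaller step is quite possible. On that footing compound 4 is estimated at 30% in this assay, with a plausible range from 18% to 42%.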

Compound 4, a percentage reported as activity, at one dose (the size of the read-out at that dose, not a potency): 27.8%
Beside the measured number, compound 4's estimate is 2.2 percentage points above it, and the stated range covers the measured number.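

In this assay, the swap of 1-hydroxyethyl for hydroxymethyl, now made on a second core, gave a number 4.2 percentage points higher from compound 3 to compound 4 (within the scatter). Set beside the earlier instance of the same swap, the two steps point the same way and cannot be told apart in size: the same change on two cores in this assay, a number 10 percentage points higher (within the scatter) from compound 2 to compound 1 and a number 4.2 percentage points higher (within the scatter) from compound 3 to compound 4, 5.8 percentage points apart, within the scatter of two such steps. This means the change behaves alike on these two cores, with no sign that the core alters its effect, but each step on its own lies within the scatter, so the data do not establish that the swap raises the read-out at all, and two cores are too few to predict its behaviour on a third.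

The compounds shown vary this side chain only between 1-hydroxyethyl and hydroxymethyl, which leaves open what a longer chain, an amine or a carboxylic acid would do in the same place. As far as these compounds go, the read-out also comes from a single dose at a single stated time, so it remains unknown whether the small gaps seen here would widen, hold or vanish at other doses or times.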